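A few compounds are considered here, and "the series" means these few. Any claim that something is new, unique, unknown or untested is made for them only; others in the source may bear on it.

Working notes on the series. Going by the values given here, in a functional assay on HCT-116 cells (Homo sapiens) for antiproliferative activity, read by CCK-8 assay, with a stated time of 72 h (a lower number here means a stronger inhibitor, a higher number a weaker inhibitor), compound 1 `Nc1ccccc1NC(=O)c1ccc(COc2ccccc2)cc1` gives 4890 nM and compound 2 `COc1ccc(OCc2ccc(C(=O)Nc3ccccc3N)cc2)cc1` gives 2020 nM, the lower of the two numbers so far. The next structure is compound 3 `CC(C)c1ccc(OCc2ccc(C(=O)Nc3ccccc3N)cc2)cc1`, with isopropyl in place of methoxy on an aromatic carbon, para to a large group: isopropyl in place of methoxy on an aromatic carbon. Among the compounds with values here, only one measured step bears on this place, namely a 2.4-fold lower number from compound 1 to compound 2 (0.38 log units; beyond the scatter), where methoxy replaced hydrogen. Within the data shown here, no measured compound carries isopropyl, so that step sets a scale for change here but gives no direct reading of the new group. A step of similar size in either direction is possible in this assay, but the expectation is none beyond the scatter, with a slight lean to a higher number. The expected step is a 1.3-fold higher number from compound 2 to compound 3 (0.11 log units; within the scatter). Compound 3 is expected near 2600 nM, with an estimated range of 1100 nM to 6000 nM.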

Compound 3, half-maximal inhibitory concentration: 4570 nM
Compound 3: the middle estimate sits 1.8-fold (0.24 log units) below what was measured; low and high end bracket the measured number.
By their numbers in this assay, from the lowest: compound 2; then compounds 3 and 1 (each within the scatter of the next).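

The position is not simply tolerant of any added group: a 2.3-fold higher number from compound 2 to compound 3 (0.35 log units; beyond the scatter), so in this assay the exchange of methoxy for isopropyl has a readable direction, which the earlier pair alone could not show. Isopropyl in place of hydrogen gives a 1.1-fold lower number from compound 1 to compound 3 (0.03 log units; within the scatter), so the shift seen with methoxy, a 2.4-fold lower number from compound 1 to compound 2 (0.38 log units; beyond the scatter), does not carry over to every group para to a large group. Nothing measured here explains the difference between methoxy and isopropyl.

The compounds shown leave open whether the lower number of compound 2 goes with the oxygen of methoxy, which a hydroxyl, an ethoxy or a dimethylamino group in the same place would test. Also open, from the compounds shown here alone, is how a chlorine or a carboxylic acid there would stand against compound 2.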